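The compounds below may be only part of what the source reports. "The series", "measured", "known", "first", "only" and "open" are said of these compounds alone.

Two compounds anchor this account. Compound 1 `Oc1cccc(-c2cc(-c3ccco3)cc(-c3ccccc3O)n2)c1` gives 820 nM in a functional assay on T47D cells (Homo sapiens) for cytotoxicity, read by CCK-8 assay; on this read-out lower numbers stand for stronger inhibition and higher numbers for weaker inhibition. Among the compounds with values here, compound 2 `Oc1cccc(-c2cc(-c3ccco3)cc(-c3cccc(O)c3)n2)c1` gives 3520 nM in this assay, the highest of the two numbers recorded, and the only measured step, a 4.3-fold higher number from compound 1 to compound 2 (0.63 log units; beyond the scatter), separates it from compound 1. Compound 3 `Oc1cccc(-c2cc(-c3ccccn3)cc(-c3cccc(O)c3)n2)c1` is not yet measured. It differs from compound 2 by pyridin-2-yl in place of furan-2-yl on an aromatic carbon. The measured step concerns an exchange of hydroxyphenyl groups and does not bear on replacing the furan-2-yl group; its size only shows that a single change on the shared core can move the number beyond the scatter. Within the data shown here, with no step that speaks to this exchange, no direction can be inferred, and the step of a 1.0-fold lower number from compound 2 to compound 3 (0.00 log units; within the scatter) is expected to be small. For compound 3, the estimated value in this assay is 3500 nM, with a range from 1200 nM to 10000 nM.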

Compound 3, half-maximal inhibitory concentration: 1410 nM
Compound 3: the middle estimate sits 2.5-fold (0.39 log units) above what was measured; the measured number falls inside the stated range.
By their numbers in this assay, from the lowest: compounds 1 and 3 (each within the scatter of the next); then compound 2.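

Exchanging furan-2-yl for pyridin-2-yl opposite the ring nitrogen gives a 2.5-fold lower number from compound 2 to compound 3 (0.40 log units; beyond the scatter) in this assay, so this position, which the earlier pair left untouched, can also move the number beyond the scatter. The entering ring is six-membered rather than five-membered, while the two groups match in their hydrogen-bond donor and acceptor counts and neither carries a net charge. Nothing at hand accounts for the shift. On these data alone, whether a phenyl, a pyridin-3-yl or an amine at this position would move the number further remains open. As far as these compounds go, it is also open whether the same exchange would give a step of similar size when a 2-hydroxyphenyl group stands on the shared core, as it does in compound 1.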